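A few compounds are considered here, and "the series" means these few. Any claim that something is new, unique, unknown or untested is made for them only; others in the source may bear on it.

Working notes on the series around the shared core of compound 1 `c1ccc(-c2cnccn2)c(OCC2=NCCN2)c1`. In a functional assay for activation of Alpha-1B adrenergic receptor (Homo sapiens), read by calcium flux (a lower number here means a smaller maximal response, a higher number a larger maximal response), compound 1 gives 46%, compound 2 `c1coc(-c2ccccc2OCC2=NCCN2)c1` gives 110% and compound 3 `c1csc(-c2ccccc2OCC2=NCCN2)c1` gives 112%. Compound 3 stands at the upper end of the three numbers, with compound 2 within the scatter of it and compound 1 far below: a number 64 percentage points higher from compound 1 to compound 2 (beyond the scatter), a number 66 percentage points higher from compound 1 to compound 3 (beyond the scatter), whereas a number 2 percentage points higher from compound 2 to compound 3 (within the scatter).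

The next member is compound 4 `c1ccc(-c2ccoc2)c(OCC2=NCCN2)c1`. (furan-3-yl in place of thiophen-2-yl on an aromatic carbon). The step that bears on this change most closely is the exchange of furan-2-yl for thiophen-2-yl, which stayed within the scatter; the two large steps from compound 1 concern a different kind of ring and say little about a move from one five-membered ring with one hetero atom to another. A step within the scatter is therefore expected in this assay for compound 4, in no particular direction: a number 7 percentage points lower from compound 3 to compound 4 (within the scatter). The estimate for compound 4 in this assay is 105%, within 85% to 125%.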

Compound 4, largest response reached (reported as maximum), in percent of the reference or control that the assay uses: 111%
Compound 4: the middle estimate sits 6 percentage points below what was measured; measured number inside the range.
By their numbers in this assay, from the lowest: compound 1; then compounds 2, 4 and 3 (each within the scatter of the next).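

In this assay, furan-3-yl in place of furan-2-yl gives a number 1 percentage points higher from compound 2 to compound 4 (within the scatter) and furan-3-yl in place of thiophen-2-yl gives a number 1 percentage points lower from compound 3 to compound 4 (within the scatter), so at this aromatic carbon neither the hetero atom of the five-membered ring nor the choice between furan-2-yl and furan-3-yl yields a step beyond the scatter among these three compounds. For the compounds shown here, the exchange for pyrazin-2-yl remains large, with a number 65 percentage points higher from compound 1 to compound 4 (beyond the scatter), which leaves compound 1 as the only compound apart from the others. Nothing available explains either the close agreement among the five-membered rings or the gap to pyrazin-2-yl.

Still open, from the compounds shown here alone, is whether phenyl or pyridin-2-yl at this place would group with compound 2, compound 3 and compound 4, or with compound 1. Going by these compounds, the response to an amine or a carboxylic acid on this aromatic carbon also remains open.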